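This account rests on a few compounds, and the source may have more. Where it says the series, first, only, none or still open, it means among the compounds named here.

Series notes. Two members of the series have a value in an ADME assay on Vero cells (Chlorocebus sabaeus) for cytotoxicity, read by neutral red uptake, tested at 394 ug/mL (a higher number here means a weaker effect of the compound at the concentration tested, a lower number a stronger effect), so far. Compound 1 `O=C1CSC(c2cccc(Cl)c2)N1CCN1CCCCC1` gives 45% in this assay, the lower of the two numbers; compound 2 `COc1ccccc1C1SCC(=O)N1CCN1CCCCC1` gives 67% in this assay, a reading beyond the scatter above that of compound 1. Compound 3 `O=C1CSC(c2ccc(F)cc2)N1CCN1CCCCC1` is the next member and is still to be measured in this assay. It differs from compound 1 in one place: 4-fluorophenyl in place of 3-chlorophenyl on a saturated ring carbon. For the measured compounds named here, no single-point step within the measured pair is available to calibrate this change. The expectation is a modest step upward from compound 1 to compound 3, a number 13 percentage points higher from compound 1 to compound 3 (beyond the scatter), with the possibility that it lies within the scatter. For compound 3 in this assay the estimate is 58%, with a range from 40% to 78%.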

Compound 3, a percentage reported as activity, at one concentration (the size of the read-out at that concentration, not a potency): 52%
Estimate against measurement, compound 3: 6 percentage points above, within the range that was stated.
By their numbers in this assay, from the lowest: compounds 1 and 3 (each within the scatter of the next); then compound 2.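

In this assay, the exchange of 3-chlorophenyl for 4-fluorophenyl on the saturated ring carbon reads as a number 7 percentage points higher from compound 1 to compound 3 (within the scatter), so the two groups are not told apart at this position. This single step alters the halogen and its place on the phenyl ring together, and the two contributions cannot be separated. No measurement bearing on a cause for this step is at hand.

Open, from the compounds shown here alone, is whether an unsubstituted phenyl, or a phenyl carrying a carboxylic acid, on this saturated ring carbon would give a step beyond the scatter from compound 1.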